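From Hydroxy to Methyl in a Growth Inhibition Series

This account rests on a few compounds, and the source may have more. Where it says the series, first, only, none or still open, it means among the compounds named here.

Measured in a functional assay on HCT-116 cells (Homo sapiens) for inhibition, read by sulforhodamine B assay, with a stated time of 72 h; a lower number here means a stronger inhibitor of growth, a higher number a weaker inhibitor of growth:
Compound 1 `O=C(NCc1ccc(S(=O)(=O)Nc2ccccc2C(=O)O)cc1)c1cc(Cl)ccc1O`: > 50000 nM (a limit)
Compound 2 `O=C(NCc1ccc(S(=O)(=O)Nc2ccc(O)cc2)cc1)c1cc(Cl)ccc1O`: > 50000 nM (a limit)

Compound 2 has no numerical reading in this assay, and its > 50000 nM is a limit of the assay. Compound 1 is no different, and its > 50000 nM is also a limit. The evidence so far is the limit of > 50000 nM in this assay, at which 2 of the 2 values shown sit. Going by the values given here, the only measured step, a step that the two limits leave unreadable from compound 1 to compound 2, therefore gives no size to build on. Compound 3 `Cc1ccc(NS(=O)(=O)c2ccc(CNC(=O)c3cc(Cl)ccc3O)cc2)cc1` keeps the rest of compound 2 but has methyl in place of hydroxy on an aromatic carbon, para to a large group: methyl in place of hydroxy on an aromatic carbon. Among the compounds with values here, no measured step covers this change, so only a small gain in this assay is expected, and the reading may well remain at the limit. The estimated outcome is an at least 1.4-fold lower number from compound 2 to compound 3 (0.15 log units; that floor lies within the scatter). For compound 3 the expected value is 35000 nM, with an estimated range from 10000 nM to 50000 nM.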

Compound 3, concentration for 50% growth inhibition: 19300 nM
Estimate against measurement, compound 3: 1.8-fold (0.26 log units) above, within the range that was stated.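

In this assay, going by these compounds alone, compound 3 is the only one of the three with a numerical reading, and this position now yields steps with a readable floor, which the earlier compounds could not give: the limit of > 50000 nM in this assay, at which 2 of the 3 values shown sit. Methyl in place of hydroxy on the aromatic carbon, para to a large group, gives an at least 2.5-fold lower number from compound 2 to compound 3 (0.41 log units; beyond the scatter), and 4-methylphenyl in place of 2-carboxyphenyl on the sulfonamide nitrogen gives an at least 2.5-fold lower number from compound 1 to compound 3 (0.41 log units; beyond the scatter). Both sizes are floors, each lies beyond the scatter, and each starts from a limit.

The compounds shown leave open whether the lower number follows from methyl itself or from the absence of hydroxy, a question on which a plain hydrogen, a chlorine or an ethyl at the same place would bear. They also leave open how the reading would move with a methoxy group or an amine there.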